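Trifluoromethyl in place of nitro: working notes

The source may hold more compounds than are shown below. What is called first, only, known or untested is meant among the compounds shown, and "the series" means these compounds.

compound 1 `O=C(/C=C/c1ccccc1)c1cccc([N+](=O)[O-])c1` gives 4300 nM
compound 2 `O=C(/C=C/c1cccc([N+](=O)[O-])c1)c1ccccc1` gives 2800 nM
compound 3 `O=C(/C=C/c1ccccc1)c1ccc(C(F)(F)F)cc1` gives > 20000 nM (a limit of the assay)

In an ADME assay on A2780 cells (Homo sapiens) for inhibition, read by trypan blue exclusion, with a stated time of 72 h (on this read-out higher numbers stand for weaker inhibition of growth and lower numbers for stronger inhibition of growth), compound 1 gives 4300 nM and compound 2 gives 2800 nM as two numbers within the scatter of each other. Compound 3 stands at > 20000 nM as a limit of the assay, not a number.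

Compound 4 `O=C(/C=C/c1ccccc1)c1cccc(C(F)(F)F)c1` keeps the core of compound 1, with trifluoromethyl in place of nitro on an aromatic carbon, meta to a large group (trifluoromethyl in place of nitro on an aromatic carbon). For the measured compounds named here, no measured pair isolates this exchange. The expectation leans on compound 3, which also carries trifluoromethyl and gives the limit > 20000 nM in this assay as its only result. A rise in the number just beyond the scatter, meaning weaker inhibition of growth, is expected for the step of a 2.3-fold higher number from compound 1 to compound 4 (0.37 log units; beyond the scatter) in this read-out. For compound 4 the estimated value is 10000 nM and 3000 nM to 20000 nM is the expected range.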

Compound 4, concentration for 50% growth inhibition: > 20000 nM
Compound 4 gave a limit, no number; the forecaster's own chance of this, stated with the estimate: 30%; at least 2.0-fold (0.30 log units) between middle value and limit.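

For the compounds shown here, at this position, on an aromatic carbon, meta to a large group, trifluoromethyl in place of nitro weakens inhibition of growth in this assay, with an at least 4.6-fold higher number from compound 1 to compound 4 (0.66 log units; beyond the scatter), the one measured pair that isolates this exchange. Compound 4 stands at a limit of the assay, not a number. Moving trifluoromethyl from its place in compound 3 to its place in compound 4 therefore gives no readable difference, and both compounds end at the same limit: the limit of > 20000 nM in this assay, at which 2 of the 4 values shown sit.

Still open, as far as these compounds go, is whether an amine or a nitrile at this position would keep inhibition of growth near that of compound 1. From the compounds shown here alone, how far compound 4 lies past the limit also remains open.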